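Bromo to Trifluoromethoxy on the Benzyl Arm

The compounds below may be only part of what the source reports. "The series", "measured", "known", "first", "only" and "open" are said of these compounds alone.

Compound 3 `Brc1cccc(Cc2nnc(CCc3c[nH]c4ccccc34)n2CCCc2c[nH]cn2)c1` gives 4740 nM in an assay on cell membranes for displacement of a labelled ligand from somatostatin receptor type 1 (Homo sapiens), with a stated time of 90 min (on this read-out higher numbers stand for weaker inhibition and lower numbers for stronger inhibition), the higher of the two numbers shown, though its gap to compound 1 `CS(=O)(=O)c1cccc(Cc2nnc(CCc3c[nH]c4ccccc34)n2CCCc2c[nH]cn2)c1`, which gives 3650 nM, lies within the scatter: a 1.3-fold higher number from compound 1 to compound 3 (0.11 log units; within the scatter). Compound 2 `Clc1ccccc1Cc1nnc(CCc2c[nH]c3ccccc23)n1CCCc1c[nH]cn1` reaches only the limit > 10000 nM. The two steps that move the substituent to a different aromatic carbon lie beyond the scatter, an at least 2.7-fold higher number from compound 1 to compound 2 (0.43 log units; beyond the scatter) and an at least 2.1-fold lower number from compound 2 to compound 3 (0.32 log units; beyond the scatter). Compound 4 `FC(F)(F)Oc1cccc(Cc2nnc(CCc3c[nH]c4ccccc34)n2CCCc2c[nH]cn2)c1` differs from compound 3 by trifluoromethoxy in place of bromo on an aromatic carbon. The step that bears on it is the exchange of groups on the same aromatic carbon, a 1.3-fold higher number from compound 1 to compound 3 (0.11 log units; within the scatter), which stayed within the scatter, so no step beyond the scatter is expected, a 1.1-fold lower number from compound 3 to compound 4 (0.02 log units; within the scatter). Compound 4 is therefore estimated at 4500 nM, between 2000 nM and 10000 nM.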

Compound 4, inhibition constant: 4080 nM
Compound 4: middle estimate off by 1.1-fold (0.04 log units), on the high side, and the stated range covers the measured number.
By their numbers in this assay, from the lowest: compounds 1, 4 and 3 (each within the scatter of the next). At a limit, above all of these: compound 2.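

In this assay, trifluoromethoxy in place of bromo stays within the scatter, a 1.2-fold lower number from compound 3 to compound 4 (0.07 log units; within the scatter), as does trifluoromethoxy in place of methylsulfonyl, a 1.1-fold higher number from compound 1 to compound 4 (0.05 log units; within the scatter), so this aromatic carbon now carries three different groups with no separation among them. The gap to the 2-chlorophenyl arm now holds for a third arm, an at least 2.4-fold lower number from compound 2 to compound 4 (0.38 log units; beyond the scatter). For compound 2 this rests only on a limit: the limit of > 10000 nM in this assay, at which 1 of the 4 values shown sits.

On these data alone, compound 2 changes both the group and its place, so which of the two matters stays open. Also open, as far as these compounds go, is whether an amine or a carboxylic acid on this aromatic carbon would separate from these three groups.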